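Replacing the dichlorophenyl of compound 3 with a sulfamoylphenyl

A few compounds are considered here, and "the series" means these few. Any claim that something is new, unique, unknown or untested is made for them only; others in the source may bear on it.

Of the compounds shown here, three sharing one core have been measured in an assay for binding affinity to dual specificity mitogen-activated protein kinase kinase 4 (Homo sapiens), read by KINOMEscan, tested at 100 nM; a lower number here means a stronger effect, a higher number a weaker effect of the compound at the concentration tested. Compound 1, `CCCS(=O)(=O)Nc1ccc(F)c(C(=O)c2n[nH]c3ncc(-c4ccccc4F)cc23)c1F`, gives 2%. Compound 2, `CCCS(=O)(=O)Nc1ccc(F)c(C(=O)c2n[nH]c3ncc(-c4ccc(N)cc4)cc23)c1F`, gives 0.1%. Compound 3, `CCCS(=O)(=O)Nc1ccc(F)c(C(=O)c2n[nH]c3ncc(-c4ccc(Cl)cc4Cl)cc23)c1F`, gives 22%, the highest of the three numbers: it sits a number 20 percentage points higher from compound 1 to compound 3 (beyond the scatter) and a number 21.9 percentage points higher from compound 2 to compound 3 (beyond the scatter), both steps beyond the scatter, whereas the step of a number 1.9 percentage points lower from compound 1 to compound 2 (within the scatter) lies within it.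

Compound 4, `CCCS(=O)(=O)Nc1ccc(F)c(C(=O)c2n[nH]c3ncc(-c4ccc(S(N)(=O)=O)cc4)cc23)c1F`, differs from compound 3 in one place: 4-sulfamoylphenyl in place of 2,4-dichlorophenyl on an aromatic carbon. For the measured compounds named here, the steps that bear on this change are the two that led to compound 3, each a modest rise when 2,4-dichlorophenyl entered. Compound 4 carries instead a 4-sulfamoylphenyl, and compound 2 with its 4-aminophenyl gives the lowest number seen. The step of a number 19 percentage points lower from compound 3 to compound 4 (beyond the scatter) is therefore expected to run downward, beyond the scatter, back toward the values of compounds 1 and 2. For compound 4 in this assay an estimate of 3% is made, with a range from 0.1% to 15%.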

Compound 4, a percentage reported as activity, at one concentration (the size of the read-out at that concentration, not a potency): 0.25%
Beside the measured number, compound 4's estimate is 2.8 percentage points above it; measured number inside the range.
By their numbers in this assay, from the lowest: compounds 2, 4 and 1 (each within the scatter of the next); then compound 3.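

Set against the 2,4-dichlorophenyl in this assay, the 4-sulfamoylphenyl on this aromatic carbon gives a number 21.8 percentage points lower from compound 3 to compound 4 (beyond the scatter), which shows that this place on the shared core accepts a substituted phenyl carrying hydrogen-bond donor and acceptor atoms, and that a larger group in heavy atoms does not raise the number here. The sulfamoyl in place of amino gives a number 0.2 percentage points higher from compound 2 to compound 4 (within the scatter), and the 4-sulfamoylphenyl in place of 2-fluorophenyl gives a number 1.8 percentage points lower from compound 1 to compound 4 (within the scatter), so among the four compounds only the 2,4-dichlorophenyl of compound 3 stands apart. Nothing shown here explains these differences.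

The compounds shown leave open whether a carboxylic acid on the phenyl ring would keep the number at this level. They also leave open whether a single chlorine would behave like the two chlorines of compound 3.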